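Chain extension from compound 1 to compound 3

The source may hold more compounds than are shown below. What is called first, only, known or untested is meant among the compounds shown, and "the series" means these compounds.

In a functional assay on HEL cells (Homo sapiens) for cytotoxicity (on this read-out lower numbers stand for higher toxicity in this test and higher numbers for lower toxicity in this test), compound 1 (`CCCCC#Cc1cc2cn([C@@H]3O[C@H](CO)[C@@H](O)[C@H]3O)c(=O)nc2o1`) gives > 144000 nM, which is a limit and not a number. Compound 2 (`CCCCC#Cc1cc2cn([C@@H]3O[C@H](CO)[C@@H](O)[C@@H]3O)c(=O)nc2o1`) gives > 144000 nM, also a limit. Compound 1 therefore stands at the limit, and neither measured compound offers a number.

Compound 3 (`CCCCCCCCC#Cc1cc2cn([C@@H]3O[C@H](CO)[C@@H](O)[C@H]3O)c(=O)nc2o1`) keeps the core of compound 1 and differs in one place: butyl in place of hydrogen on a saturated chain carbon, four bonds along the chain from a triple-bonded carbon.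

Within the data shown here, the one measured step, a step that the two limits leave unreadable from compound 1 to compound 2, has no readable size. It also concerns (the fact that compounds 1 and 2 differ only in the configuration as drawn), not chain length, so it gives no size to carry over to compound 3. The starting point of compound 1 is a limit at > 144000 nM, so the expected outcome in this assay is a modest move toward lower numbers or no readable step. Compound 3 is expected more likely than not to be reported as a limit too. The expected step is an at least 1.3-fold lower number from compound 1 to compound 3 (0.11 log units; that floor lies within the scatter). For compound 3 the estimated value is 110000 nM, with an expected range of 40000 nM to 200000 nM.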

Compound 3, half-maximal cytotoxic concentration: 62000 nM
Estimate against measurement, compound 3: 1.8-fold (0.25 log units) above, and the stated range covers the measured number.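

In this assay, among these compounds, butyl in place of hydrogen on a saturated chain carbon, four bonds along the chain from a triple-bonded carbon, gives an at least 2.3-fold lower number from compound 1 to compound 3 (0.36 log units; beyond the scatter), the first step that can be read and one that lies beyond the scatter. Its size is a floor and not a measured gap, and compound 3 is the only compound shown that carries a number, while the others stand at a limit: the limit of > 144000 nM in this assay, at which 2 of the 3 values shown sit. The one earlier step cannot be read and concerns configuration as drawn rather than this chain, so the chain carbon is the only place shown where a change moves the read-out: the fact that compounds 1 and 2 differ only in the configuration as drawn.

Open, from the compounds shown here alone, is how the read-out runs with a longer chain such as decyl, or with an amine or a carboxylic acid in place of butyl at the same place, so one step gives no trend with chain length. Also open, going by these compounds, is whether butyl at this place gives a similar step on compound 2, whose configuration differs from that of compound 1.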